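The source may report more compounds than this note shows. Statements on the series, on what has been measured and on what is new or still open speak of the compounds shown alone.

Series notes, compounds measured so far:

compound 1, `CNS(=O)(=O)c1ccc2c(c1)C(n1ccccc1=O)=CC(C)(C)O2` — a functional assay on the whole organism (trachea) with Rattus norvegicus as the target; a lower number here means a smaller maximal response, a higher number a larger maximal response: 83%
compound 2, `CCNS(=O)(=O)c1ccc2c(c1)C(n1ccccc1=O)=CC(C)(C)O2` — this assay: 87%
compound 3, `CC1(C)C=C(n2ccccc2=O)c2cc(S(=O)(=O)Nc3ccc(C#N)cc3)ccc2O1` — this assay: 90.8%

Compound 2 stands second highest of the three numbers. Its nearest neighbour is compound 3, with a number 3.8 percentage points higher from compound 2 to compound 3 (within the scatter); its furthest is compound 1, with a number 4 percentage points higher from compound 1 to compound 2 (within the scatter). The third comparison, a number 7.8 percentage points higher from compound 1 to compound 3 (within the scatter), is of the same kind. All three measured numbers thus sit within the scatter of one another, and no ordering among them can be claimed.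

Compound 4, `CC1(C)C=C(n2ccccc2=O)c2cc(S(=O)(=O)c3ccccc3)ccc2O1`, is the next compound. Its change from compound 2 is phenyl in place of ethylamino on a sulfonyl sulfur. The measured steps all vary the group on the sulfonamide nitrogen while keeping that nitrogen; none removes the nitrogen itself, so none covers the present change exactly. The closest is the step from ethyl to an aromatic ring on that nitrogen, a number 3.8 percentage points higher from compound 2 to compound 3 (within the scatter), which stayed within the scatter. For the measured compounds named here, the series so far shows no step in this assay beyond the scatter for any change at this sulfonyl position, so no step beyond the scatter is expected here either, only a wider range than the measured steps alone would suggest. Going by these compounds, the loss of the sulfonamide nitrogen is untested.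

Compound 4 is therefore estimated at 87%, in the range 68% to 100%, meaning an expected step of no change at the digits printed from compound 2 to compound 4 (within the scatter).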

Compound 4, largest response reached (Emax), in percent of the reference or control that the assay uses: 88.1%
Compound 4: middle estimate off by 1.1 percentage points, on the low side, and the stated range covers the measured number.
By their numbers in this assay, from the lowest: compounds 1, 2, 4 and 3 (each within the scatter of the next).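

For the compounds shown here, with phenyl on the sulfonyl sulfur, the nitrogen that all the earlier compounds kept is gone, and the step against each of them can now be read in this assay: a number 1.1 percentage points higher from compound 2 to compound 4 (within the scatter), a number 2.7 percentage points lower from compound 3 to compound 4 (within the scatter) and a number 5.1 percentage points higher from compound 1 to compound 4 (within the scatter). The change takes away the one hydrogen-bond donor of the ethylamino group, yet compound 4 sits within the scatter of all three sulfonamides, so among these four compounds a sulfonamide nitrogen is not required for a maximal response of this size. No supporting data bear on why this replacement leaves the read-out within the scatter.

All steps at this position remain within the scatter, so the compounds shown do not reveal any group on the sulfonyl sulfur that moves the response beyond it, and whether a small alkyl such as methyl, or a phenyl carrying a carboxylic acid or a primary amine, would do so remains open. Going by these compounds, whether the same tolerance holds on a core other than the shared one also remains open.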